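Trimming Ethyl to Methyl: Expected Tolerance in Cells

The source may hold more compounds than are shown below. What is called first, only, known or untested is meant among the compounds shown, and "the series" means these compounds.

Three compounds built on one shared core have been run in a toxicity assay on THP-1 cells (Homo sapiens) for inhibition; a higher number here means that more compound is tolerated, a lower number that less compound is tolerated. Compound 1 `COc1ccc(-c2cnc(NC(=O)c3cccnc3)n2C)cc1` carries a methyl on the ring nitrogen and a pyridine amide; in this assay compound 1 reaches only the limit > 100000 nM, a boundary of the test rather than a number. Compound 2 `Cn1c(-c2ccc(Cl)cc2)cnc1NC(=O)c1ccc(F)cc1` differs in its aryl group and its amide; in this assay compound 2 gives 37000 nM. Compound 3 `CCn1c(-c2ccc(OC)cc2)cnc1NC(=O)c1ccc(F)cc1` is the starting point here; in this assay compound 3 also sits at the limit > 100000 nM, again a boundary and not a measured number. On the values shown, compound 3 therefore stands with compound 1 at the tolerated end, as the limit of > 100000 nM in this assay, at which 2 of the 3 values shown sit, records, while compound 2 alone gave a measured number.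

Compound 4 `COc1ccc(-c2cnc(NC(=O)c3ccc(F)cc3)n2C)cc1` is the compound still to be tested. Its change from compound 3 is hydrogen in place of methyl on a saturated chain carbon bound to an aromatic nitrogen. Within the data shown here, no measured pair shows this change, so any expectation rests only on the three compounds above, among which compound 1 also carries a methyl and sits at the limit. The step is expected to be an at least 1.2-fold lower number from compound 3 to compound 4 (0.09 log units; that floor lies within the scatter), that is, none beyond the usual scatter. For compound 4 the expected value in this assay is 80000 nM, with a range from 30000 nM to 150000 nM.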

Compound 4, half-maximal cytotoxic concentration: >= 50000 nM
Compound 4 ended at the assay's limit; the forecaster's own chance of this, stated with the estimate: 55%; the middle value lies beyond the limit too.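

In this assay compound 4 gives >= 50000 nM, a limit of the test and not a number, so with methyl in place of ethyl this series still offers no measured toxic concentration for the methoxy-bearing fluorobenzamide. Among these compounds, neither the change from ethyl to methyl, seen against compound 3, nor the change from pyridin-3-yl to 4-fluorophenyl, seen against compound 1, can be read, because both ends of each step are limits and the limit for compound 4 is a different one: the limit of >= 50000 nM in this assay, at which 1 of the 4 values shown sits. The one step that can be read is methoxy in place of chloro on an aromatic carbon, an at least 1.3-fold higher number from compound 2 to compound 4 (0.13 log units; that floor lies within the scatter), and this gives only a floor, so the true size of that swap may be larger, but the data do not show a change beyond the usual scatter.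

As far as these compounds go, the size of the ethyl to methyl change stays open until compound 3 and compound 4 both have real numbers rather than limits. Also open, from the compounds shown here alone, is how tolerance in cells would respond to a longer chain such as propyl at this place, or to an amine carried on that chain.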